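Pentafluorophenyl Ether Expected to Repeat the Tetrafluoro Gain

A few compounds are considered here, and "the series" means these few. Any claim that something is new, unique, unknown or untested is made for them only; others in the source may bear on it.

Compound 1 `CC(C)[C@H](NC(=O)COc1cccc2ccccc12)C(=O)N[C@@H](CC(=O)O)C(=O)COc1cccc(C(F)(F)F)c1` sets the shared core of this set. In a functional assay on Jurkat cells (Homo sapiens) (on this read-out higher numbers stand for weaker inhibition and lower numbers for stronger inhibition), compound 1 gives no number but a limit of the assay, > 100000 nM. Compound 2 `CC(C)[C@H](NC(=O)COc1cccc2ccccc12)C(=O)N[C@@H](CC(=O)O)C(=O)COc1cccc(F)c1` carries fluoro in place of trifluoromethyl on an aromatic carbon. In this assay compound 2 likewise gives only a limit, > 100000 nM. Compound 3 `CC(C)[C@H](NC(=O)COc1cccc2ccccc12)C(=O)N[C@@H](CC(=O)O)C(=O)COc1c(F)c(F)cc(F)c1F` carries 2,3,5,6-tetrafluorophenyl on the oxygen on a saturated carbon, and in this assay compound 3 gives 4500 nM. Among the measured compounds shown here, two of the three values shown thus sit at the limit of > 100000 nM in this assay, at which 2 of the 3 values shown sit, so compound 1 stands at the weak end of what has been seen, while an at least 22-fold lower number from compound 1 to compound 3 (1.34 log units; beyond the scatter) and an at least 22-fold lower number from compound 2 to compound 3 (1.34 log units; beyond the scatter) are the only readable steps; a step that the two limits leave unreadable from compound 1 to compound 2 cannot be sized.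

The unmeasured compound 4 `CC(C)[C@H](NC(=O)COc1cccc2ccccc12)C(=O)N[C@@H](CC(=O)O)C(=O)COc1c(F)c(F)c(F)c(F)c1F` differs from compound 1 in one place: 2,3,4,5,6-pentafluorophenyl in place of 3-(trifluoromethyl)phenyl on an oxygen on a saturated carbon. For the measured compounds named here, the step that bears on it most closely is the one leading to compound 3, since a ring carrying several fluorines again replaces the 3-(trifluoromethyl)phenyl group, and that step was large and toward a lower number. Compound 4 is therefore expected to show a step of an at least 33-fold lower number from compound 1 to compound 4 (1.52 log units; beyond the scatter) in this assay. For compound 4 the estimate is 3000 nM, with a range from 700 nM to 20000 nM expected to hold the measured number.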

Compound 4, half-maximal inhibitory concentration: 3050 nM
Estimate against measurement, compound 4: 1.0-fold (0.01 log units) below; the range from low to high includes it.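

In this assay, a second heavily fluorinated ring on the oxygen on a saturated carbon gives a large gain, with an at least 32-fold lower number from compound 1 to compound 4 (1.51 log units; beyond the scatter) and an at least 32-fold lower number from compound 2 to compound 4 (1.51 log units; beyond the scatter), so among the compounds shown the gain is not confined to compound 3. The added fluorine does not separate the two heavily fluorinated compounds, with a 1.5-fold lower number from compound 3 to compound 4 (0.17 log units; within the scatter), so fluoro in place of hydrogen on this ring makes no readable difference, and both compounds 3 and 4 give numbers while the rings with a single substituent in compounds 1 and 2 do not. The two large steps both start from a limit of the assay rather than a number, so they give only a minimum size: the limit of > 100000 nM in this assay, at which 2 of the 4 values shown sit.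

The compounds shown leave open how a plain phenyl ring, a difluorophenyl ring or a pentachlorophenyl ring would read at this place, and so how many fluorines are needed before a number appears at all. They also leave open whether the gain would hold if the carboxylic acid of the shared core were replaced by a methyl ester or a primary amide.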